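Chloro for fluoro carried from one core to a second

The source may report more compounds than this note shows. Statements on the series, on what has been measured and on what is new or still open speak of the compounds shown alone.

Compound 1 `COc1ccc(N/C=C\C(=O)c2cn(-c3ccccc3)nc2-c2ccc(F)cc2)cc1` and compound 3 `COc1ccc(N/C=C\C(=O)c2cn(-c3ccccc3)nc2-c2ccc(Cl)cc2)cc1` share a core and differ in one place: chloro in place of fluoro on an aromatic carbon. In a functional assay on U-87MG ATCC cells (Homo sapiens) for antiproliferative activity, read by MTT assay, with a stated time of 48 h (a higher number here means a weaker inhibitor, a lower number a stronger inhibitor), compound 1 gives 2500 nM and compound 3 gives 6890 nM, so the change made a 2.8-fold higher number from compound 1 to compound 3 (0.44 log units; beyond the scatter). Compound 2 `COc1cc(N/C=C\C(=O)c2cn(-c3ccccc3)nc2-c2ccc(F)cc2)cc(OC)c1OC` rests on a different core; how the two cores differ is not broken down here. In this assay compound 2 gives 12600 nM, a number beyond the scatter from that of compound 1 and within the scatter of that of compound 3. Compound 4 `COc1cc(N/C=C\C(=O)c2cn(-c3ccccc3)nc2-c2ccc(Cl)cc2)cc(OC)c1OC` is not yet measured and stands to compound 2 as compound 3 stands to compound 1: chloro in place of fluoro on an aromatic carbon. The place of the change is described in the same words for both pairs, so this is the same change set on the second core. For the measured compounds named here, the only precedent is the one step from compound 1 to compound 3, and a second core may carry the same change differently, so the expectation is held loosely. The expected step is a 2.4-fold higher number from compound 2 to compound 4 (0.38 log units; beyond the scatter), resting on a 2.8-fold higher number from compound 1 to compound 3 (0.44 log units; beyond the scatter). Compound 4 is thus estimated at 30000 nM in this assay, between 12000 nM and 80000 nM.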

Compound 4, half-maximal inhibitory concentration: 17800 nM
Estimate against measurement, compound 4: 1.7-fold (0.23 log units) above, and the stated range covers the measured number.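

In this assay, chloro in place of fluoro on the core of compound 2 gives a 1.4-fold higher number from compound 2 to compound 4 (0.15 log units; within the scatter), so on this core the change cannot be told from repeat variation. Set beside the step on the core of compound 1, the two results cannot be told apart: the same change on two cores in this assay, a 2.8-fold higher number (0.44 log units; beyond the scatter) from compound 1 to compound 3 and a 1.4-fold higher number (0.15 log units; within the scatter) from compound 2 to compound 4, 2.0-fold (0.29 log units) apart, within the scatter of two such steps. For the compounds shown here, this shows that the series so far gives no sign of the change behaving differently on the two cores, but it does not show that the change has the same size on both, since each core offers one pair and only one of the two steps lies beyond the scatter.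

Still open, as far as these compounds go, is how another group on that aromatic carbon, such as bromo, methyl, an amine or a carboxylic acid, would read in this assay on either core. Also open, from the compounds shown here alone, is whether the step from 4-fluorophenyl to 4-chlorophenyl would read alike on a third core.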